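A methyl-to-trifluoromethoxy swap on two related cores

A few compounds are considered here, and "the series" means these few. Any claim that something is new, unique, unknown or untested is made for them only; others in the source may bear on it.

Of the compounds shown here, three have been tested in a functional assay on MCF7 cells (Homo sapiens) for antiproliferative activity, read by MTT assay, with a stated time of 72 h; on this read-out lower numbers stand for stronger inhibition and higher numbers for weaker inhibition. Compound 1 `CCNC(=O)c1cc(Oc2ccc(NC(=O)c3nn(-c4ccccc4OC(F)(F)F)c(=O)cc3C)cc2)ccn1` gives 15500 nM, compound 2 `CCNC(=O)c1cc(Oc2ccc(NC(=O)c3nn(-c4ccccc4C)c(=O)cc3C)cc2)ccn1` gives 44300 nM, and compound 3 `CCCNC(=O)c1cc(Oc2ccc(NC(=O)c3nn(-c4ccccc4C)c(=O)cc3C)cc2F)ccn1` gives 39600 nM. Compound 3 and compound 2 differ in more than one place, and the difference between their two cores is not broken down here; their values stand within the usual scatter of each other, so no order can be read from them.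

Compound 1 and compound 2 differ in one place only: trifluoromethoxy in place of methyl on an aromatic carbon. This change made a 2.9-fold lower number from compound 2 to compound 1 (0.46 log units; beyond the scatter).

Compound 4 `CCCNC(=O)c1cc(Oc2ccc(NC(=O)c3nn(-c4ccccc4OC(F)(F)F)c(=O)cc3C)cc2F)ccn1` has not yet been measured. It relates to compound 3 exactly as compound 1 relates to compound 2: trifluoromethoxy in place of methyl on an aromatic carbon. Among the measured compounds shown here, since both changes sit at the same kind of place on the same kind of ring, the earlier step is the only guide available, and a step of similar size is expected from compound 3 to compound 4 in this assay , namely a 2.8-fold lower number from compound 3 to compound 4 (0.45 log units; beyond the scatter). On that basis, compound 4 is estimated to give 14000 nM in this assay , with a likely range from 6000 nM to 32000 nM.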

Compound 4, half-maximal inhibitory concentration: 7420 nM
For compound 4 the middle estimate is 1.9-fold (0.28 log units) above the measured one; the range from low to high includes it.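

On the core of compound 3, replacing the 2-methylphenyl group with 2-(trifluoromethoxy)phenyl gave, in this assay, a 5.3-fold lower number from compound 3 to compound 4 (0.73 log units; beyond the scatter). Set beside the earlier step, the change lowered the number on both cores, and the two step sizes cannot be told apart: the same change on two cores in this assay, a 2.9-fold lower number (0.46 log units; beyond the scatter) from compound 2 to compound 1 and a 5.3-fold lower number (0.73 log units; beyond the scatter) from compound 3 to compound 4, 1.9-fold (0.27 log units) apart, within the scatter of two such steps. This shows that the change carried over from one core to the other in direction and, within the scatter, in size, but the larger number printed for the second step cannot be read as a real gain from that core, and two pairs make no rule for any further core in the series.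

The compounds shown leave open whether a methoxy group or a chlorine atom in the same place would lower the number as well. They also leave open whether the step would hold with a longer chain, such as butyl, on the amide nitrogen, and which of the differences between the two cores, if any, affects its size.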